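The source may hold more compounds than are shown below. What is called first, only, known or untested is meant among the compounds shown, and "the series" means these compounds.

Compound 2 `Cc1ccc2nc([C@H](CC3CCN(CC(C)C)CC3)N3C(=O)CN(c4ccc(Oc5ccccc5)cc4)C3=O)n(C)c2c1` stands as the weaker of the two measured compounds: in an assay on cells for antagonist activity at Bile acid receptor (Homo sapiens), read by a luciferase reporter, with a stated time of 24 h (on this read-out higher numbers stand for weaker inhibition and lower numbers for stronger inhibition), compound 2 gives 17400 nM, while compound 1 `Cc1ccc2nc([C@H](CC3CCNCC3)N3C(=O)CN(c4ccc(Oc5ccccc5)cc4)C3=O)n(C)c2c1` gives 4510 nM. For the measured compounds named here, the one measured step, a 3.9-fold higher number from compound 1 to compound 2 (0.59 log units; beyond the scatter), shows that filling the ring nitrogen with isobutyl cost potency.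

Compound 3 `CC(=O)N1CCC(C[C@@H](c2nc3ccc(C)cc3n2C)N2C(=O)CN(c3ccc(Oc4ccccc4)cc3)C2=O)CC1` arises from compound 2 by acetyl in place of isobutyl on an amine nitrogen in a ring. Going by the values given here, only the step from compound 1 to compound 2 bears on this position, and it says that a hydrocarbon group at that nitrogen weakens inhibition; it says nothing directly about acetyl. Since acetyl is smaller than isobutyl yet still removes the free amine hydrogen of compound 1, the expected outcome lies between the two measured values, with no step beyond the scatter in either direction firmly predicted. He therefore expects compound 3 to give 10000 nM in this assay, within 3000 nM to 40000 nM, which would mean an expected step of a 1.7-fold lower number from compound 2 to compound 3 (0.24 log units; within the scatter).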

Compound 3, half-maximal inhibitory concentration: 0.2 nM
Compound 3: middle estimate off by 50000-fold (4.70 log units), on the high side; the measured number lies below the stated range.
By their numbers in this assay, from the lowest: compound 3; then compound 1; then compound 2.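

At the amine nitrogen in the ring, the group placed there decides the outcome far more strongly than the earlier step suggested: in this assay there is an 87000-fold lower number from compound 2 to compound 3 (4.94 log units; beyond the scatter), and, measured against the free nitrogen, a 23000-fold lower number from compound 1 to compound 3 (4.35 log units; beyond the scatter). Filling this nitrogen therefore does not weaken inhibition as such, since the loss seen with isobutyl, a 3.9-fold higher number from compound 1 to compound 2 (0.59 log units; beyond the scatter), gives way to a large gain with acetyl, which brings a carbonyl and one hydrogen-bond acceptor where isobutyl has none. Nothing available explains why this exchange has so large an effect.

From the compounds shown here alone, whether the gain persists with a longer acyl chain such as propanoyl, or with a methanesulfonyl group or a urea on the same nitrogen, remains open. Going by these compounds, it is also open whether a smaller alkyl group such as methyl follows isobutyl.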